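Moving the fluorine on the benzyl ether of compound 3

A few compounds are considered here, and "the series" means these few. Any claim that something is new, unique, unknown or untested is made for them only; others in the source may bear on it.

Measured compounds:
compound 1 `O=C(Nc1cccnc1)c1ccccc1OCc1cccc(F)c1` with 1600 nM
compound 2 `N#Cc1cccc(COc2ccccc2C(=O)Nc2cccnc2)c1` with 60700 nM
compound 3 `O=C(Nc1cccnc1)c1ccccc1OCc1cc(F)ccc1Cl` with 740 nM

Compound 3 stands lowest of the three in an assay on lysate for inhibition of phosphatidylcholine:ceramide cholinephosphotransferase 2 (Homo sapiens), read by HPLC, with stated times of 30 min and 2 h; on this read-out lower numbers stand for stronger inhibition and higher numbers for weaker inhibition. Its nearest neighbour is compound 1, a step of a 2.2-fold lower number from compound 1 to compound 3 (0.33 log units; beyond the scatter) from a chloro in place of hydrogen on an aromatic carbon; the furthest is compound 2, separated by an 82-fold lower number from compound 2 to compound 3 (1.91 log units; beyond the scatter). The other measured step, a 38-fold higher number from compound 1 to compound 2 (1.58 log units; beyond the scatter), comes from a cyano in place of fluoro on an aromatic carbon.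

Compound 4 `O=C(Nc1cccnc1)c1ccccc1OCc1c(F)cccc1Cl` keeps the same atoms as compound 3 but joins them differently: 2-chloro-6-fluorophenyl in place of 2-chloro-5-fluorophenyl on a saturated chain carbon bound to an oxygen on an aromatic ring. Going by the values given here, none of the measured steps tests such a rearrangement; each changes which group is present, not where it sits. The data offer no direct guide, so the step of a 1.2-fold higher number from compound 3 to compound 4 (0.09 log units; within the scatter) is expected to be small, likely within the scatter, in either direction. Compound 4 is therefore estimated at 900 nM in this assay, with a range from 300 nM to 3000 nM.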

Compound 4, half-maximal inhibitory concentration: 1500 nM
For compound 4 the middle estimate is 1.7-fold (0.22 log units) below the measured one; the measured number falls inside the stated range.
By their numbers in this assay, from the lowest: compound 3; then compounds 4 and 1 (each within the scatter of the next); then compound 2.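

In this assay, moving only the fluorine, from 2-chloro-5-fluorophenyl to 2-chloro-6-fluorophenyl, gives a 2.0-fold higher number from compound 3 to compound 4 (0.31 log units; beyond the scatter), so the group on the saturated chain carbon bound to an oxygen on an aromatic ring responds to how its atoms are arranged, and not only to which atoms are present. The gain seen when chloro was added to give compound 3 does not carry over to this arrangement, since the step of a 1.1-fold lower number from compound 1 to compound 4 (0.03 log units; within the scatter) leaves the two compounds indistinguishable. The 3-cyanophenyl group stays clearly apart from this arrangement too, with a 40-fold lower number from compound 2 to compound 4 (1.61 log units; beyond the scatter).

Nothing given here accounts for these differences in terms of a measured property. As far as these compounds go, it remains open how a methoxy group or an amine would fare in place of the fluorine on this ring.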